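The compounds below may be only part of what the source reports. "The series", "measured", "known", "first", "only" and "open" are said of these compounds alone.

The compounds measured so far in a functional assay on HepG2 cells (Homo sapiens) for inhibition, read by sulforhodamine B assay, with a stated time of 72 h; a higher number here means a weaker inhibitor, a lower number a stronger inhibitor:

Compound 1, `C[C@H](Nc1ncnc2[nH]cnc12)c1nn(-c2cccnc2)c2cc(Cl)ccc12`, gives > 40000 nM, which is a limit of the assay and not a number.
Compound 2, `C[C@H](Nc1ncnc2[nH]cnc12)c1nn(-c2cccnc2)c2cc(F)ccc12`, gives 37500 nM.
Compound 3, `C[C@H](Nc1ncnc2[nH]cnc12)c1nn(-c2ccccn2)c2cc(F)ccc12`, gives 29900 nM.

Compound 3 has the lower of the two numbers, but compound 2 sits within the scatter of it, so no order between them can be claimed. Compound 4, `C[C@H](Nc1ncnc2[nH]cnc12)c1nn(-c2ccncc2)c2cc(F)ccc12`, differs from compound 3 by pyridin-4-yl in place of pyridin-2-yl on an aromatic nitrogen. Among the compounds with values here, only one measured step bears on this kind of change: a 1.3-fold lower number from compound 2 to compound 3 (0.10 log units; within the scatter), which also exchanged one pyridyl group for another on an aromatic nitrogen and stayed within the scatter. For compound 4 no step beyond the scatter is therefore expected in either direction, and the estimated step is a 1.0-fold higher number from compound 3 to compound 4 (0.00 log units; within the scatter). Compound 4 is estimated at 30000 nM, with a range from 12000 nM to 75000 nM.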

Compound 4, half-maximal inhibitory concentration: 23100 nM
Compound 4: the middle estimate sits 1.3-fold (0.11 log units) above what was measured; measured number inside the range.
By their numbers in this assay, from the lowest: compounds 4, 3 and 2 (each within the scatter of the next). At a limit, above all of these: compound 1.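

With pyridin-4-yl on the aromatic nitrogen, all three pyridyl groups can now be set side by side in this assay, and none stands apart: a 1.3-fold lower number from compound 3 to compound 4 (0.11 log units; within the scatter), and a 1.6-fold lower number from compound 2 to compound 4 (0.21 log units; within the scatter). Shifting where the ring nitrogen sits within this pyridyl group therefore makes no readable difference in these fluoro compounds. The chloro compound 1 gives a limit, not a number: the limit of > 40000 nM in this assay, at which 1 of the 4 values shown sits.

Going by these compounds, it remains open whether a ring of a different kind at this place, such as a plain phenyl or a phenyl carrying an amine or a carboxylic acid, would move the number beyond the scatter.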